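Moving the fluorine on the phenyl ring: compound 1 to compound 3

This account rests on a few compounds, and the source may have more. Where it says the series, first, only, none or still open, it means among the compounds named here.

Measured compounds:
compound 1, `C[C@H](c1ccc(C(=O)NCCC(=O)O)cc1)N1C(=O)C(c2ccccc2F)=N[C@]12CC[C@@H](C(C)(C)C)CC2`: > 10000 nM
compound 2, `CC(C)(C)CC[C@H](c1ccc(C(=O)NCc2nn[nH]n2)cc1)N1C(=O)C(c2cccc(C(F)(F)F)c2)=N[C@]12CC[C@@H](C(C)(C)C)CC2`: 140 nM

In an assay on membranes from liver for displacement of a labelled ligand from Glucagon receptor (Mus musculus), read by scintillation counting, with a stated time of 60 min (on this read-out lower numbers stand for stronger inhibition and higher numbers for weaker inhibition), compound 1 gives > 10000 nM, which is a limit of the assay rather than a number. Compound 1 therefore stands at the limit of > 10000 nM in this assay, at which 1 of the 2 values shown sits, the weaker end of the two values shown. In this assay compound 2 gives 140 nM. Going by the values given here, compound 2 differs from compound 1 in several places at once, so no single step joins the two and their values can only be set side by side.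

Compound 3, `C[C@H](c1ccc(C(=O)NCCC(=O)O)cc1)N1C(=O)C(c2cccc(F)c2)=N[C@]12CC[C@@H](C(C)(C)C)CC2`, is not yet measured. Relative to compound 1 the change is 3-fluorophenyl in place of 2-fluorophenyl on a carbon with a double bond to nitrogen. Among the compounds with values here, no measured pair isolates this change, so the size of the step can only be guessed from the two values shown. A modest gain, at the edge of the scatter, is expected for the step of an at least 1.4-fold lower number from compound 1 to compound 3 (0.15 log units; that floor lies within the scatter). Compound 3 is thus estimated at 7000 nM, with a range from 2000 nM to 25000 nM.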

Compound 3, half-maximal inhibitory concentration: 4400 nM
Compound 3: middle estimate off by 1.6-fold (0.20 log units), on the high side; the range from low to high includes it.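

In this assay, moving the fluorine matters at this position: with the atoms unchanged and the rest of the molecule the same, 3-fluorophenyl in place of 2-fluorophenyl on the carbon with a double bond to nitrogen gives an at least 2.2-fold lower number from compound 1 to compound 3 (0.35 log units; beyond the scatter). This gives the series with the carboxylic acid chain a first readable value, and it shows that the placement of one fluorine on this phenyl ring can by itself shift the read-out. Only one side of the step's size is fixed, because the value of compound 1 is a limit of the assay and not a number: the limit of > 10000 nM in this assay, at which 1 of the 3 values shown sits.

Going by these compounds, how far the gain could extend remains open, as does how an unsubstituted phenyl, a chlorophenyl or a methoxyphenyl would stand on the core of compound 3. Also open, on these data alone, is whether the same fluorine move would give a step of similar direction and size if a longer chain replaced the methyl group or an amine replaced the carboxylic acid.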